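Benzyl Thioether in Place of a Pyrimidinyl Ether

This account rests on a few compounds, and the source may have more. Where it says the series, first, only, none or still open, it means among the compounds named here.

This account follows three measured compounds and one whose result is still awaited. For the measured compounds named here, compound 1 `O=C(COCc1ccccc1)N1CCN(c2cc(Cl)ccn2)CC1` is the first of them; in a functional assay on HEK293 cells for positive allosteric modulation of metabotropic glutamate receptor 5 (Homo sapiens), read by FLIPR and calcium flux (a higher number here means that more compound is needed for the effect, a lower number that less compound is needed), compound 1 gives 570 nM. Compound 2 `O=C(COCc1ccncc1)N1CCN(c2ccc(Cl)cc2)CC1` gives 1300 nM in this assay, and compound 3 `O=C(COCc1ncccn1)N1CCN(c2ccc(Cl)cc2Cl)CC1` gives 18000 nM. Compound 3 thus stands with the highest number of the three, and its distance to each of the other two lies beyond the scatter of repeated measurements, with compound 2 the nearer and compound 1 the further of the pair.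

Compound 4 `O=C(CSCc1ccccc1)N1CCN(c2ccc(Cl)cc2Cl)CC1` carries benzylsulfanyl in place of (pyrimidin-2-yl)methoxy on a saturated chain carbon bound to a carbonyl carbon. Going by the values given here, no measured pair in this set differs in only that one place, so the size of the step is an expectation rather than a known quantity. Compound 4 keeps the core of compound 3 but gains the benzyl group that compound 1 shows with 570 nM, so a lower number is expected for compound 4 in this assay. The expected step of a 9.0-fold lower number from compound 3 to compound 4 (0.95 log units; beyond the scatter) is estimated to be downward and beyond the scatter. Compound 4 is estimated at 2000 nM, within a range from 500 nM to 8000 nM.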

Compound 4, half-maximal effective concentration: 7100 nM
Compound 4: middle estimate off by 3.6-fold (0.55 log units), on the low side; measured number inside the range.
By their numbers in this assay, from the lowest: compound 1; then compound 2; then compound 4; then compound 3.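

In this assay, benzylsulfanyl in place of (pyrimidin-2-yl)methoxy on a saturated chain carbon bound to a carbonyl carbon gives a 2.5-fold lower number from compound 3 to compound 4 (0.40 log units; beyond the scatter), a modest step. For the compounds shown here, this is the first comparison in the set that isolates one place, and it shows that this position responds to the exchange, though only modestly, when the rest of the structure is held constant. No measurement shown here accounts for the step.

On these data alone, the change replaces the ring and the linking oxygen together, so the share of each in the step remains open; a (pyrimidin-2-yl)methylsulfanyl group on the same core would divide the two. Also open, as far as these compounds go, is whether the step would keep its direction and size on another core, such as that of compound 1 or compound 2.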